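Morpholin-4-yl on the sulfonyl sulfur: compound 3 to compound 4

The compounds below may be only part of what the source reports. "The series", "measured", "known", "first", "only" and "open" are said of these compounds alone.

In an ADME assay on microsomes from liver (Homo sapiens) for pharmacokinetics, read by LC-MS, with a stated time of 60 min, tested at 1 uM (a lower number here means slower removal, a higher number faster removal of the compound), compound 3 `CCC(=O)N1CCC(S(=O)(=O)c2ccc(CNC(=O)N3Cc4ccncc4C3)cc2)CC1` gives 11 mL/min/kg. Compound 1 `O=C(NCc1ccc(S(=O)(=O)c2cccc(C(F)(F)F)c2)cc1)N1Cc2ccncc2C1` gives 14 mL/min/kg and compound 2 `O=C(NCc1ccc(S(=O)(=O)c2cncc(C(F)(F)F)c2)cc1)N1Cc2ccncc2C1` gives 13 mL/min/kg, so compound 3 stands within the scatter of both.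

Compound 4 `O=C(NCc1ccc(S(=O)(=O)N2CCOCC2)cc1)N1Cc2ccncc2C1` carries morpholin-4-yl in place of 1-propanoylpiperidin-4-yl on a sulfonyl sulfur.

Three measured steps change the group at this same place: a 1.1-fold lower number from compound 1 to compound 2 (0.03 log units; within the scatter), a 1.3-fold lower number from compound 1 to compound 3 (0.10 log units; within the scatter) and a 1.2-fold lower number from compound 2 to compound 3 (0.07 log units; within the scatter). All three lie within the scatter, and none of the three compounds goes against this flat picture in this assay. No measured compound carries morpholin-4-yl, so the new group itself remains untested, and the range is kept wide for that reason.

No change beyond the scatter is expected. The expected move is a 1.1-fold lower number from compound 3 to compound 4 (0.04 log units; within the scatter). For compound 4 the estimated clearance is 10 mL/min/kg, with an expected range from 6 mL/min/kg to 17 mL/min/kg.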

Compound 4, clearance: 9 mL/min/kg
Beside the measured number, compound 4's estimate is 1.1-fold (0.05 log units) above it, and the stated range covers the measured number.
By their numbers in this assay, from the lowest: compounds 4, 3, 2 and 1 (each within the scatter of the next).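

In this assay the flat picture at the sulfonyl sulfur now extends to morpholin-4-yl, with a 1.2-fold lower number from compound 3 to compound 4 (0.09 log units; within the scatter) and a 1.4-fold lower number from compound 2 to compound 4 (0.16 log units; within the scatter) and also a 1.6-fold lower number from compound 1 to compound 4 (0.19 log units; within the scatter) all inside the scatter. Within the data shown here, compound 4 is the first of the series with a ring nitrogen on the sulfonyl sulfur, so neither that link nor the smaller group (fewer heavy atoms than 1-propanoylpiperidin-4-yl) moves the number beyond the scatter. No measured evidence accounts for these four numbers lying so close together.

From the compounds shown here alone, whether a carboxylic acid, a free piperidine amine or an open alkyl chain on the sulfonyl sulfur would stay within this narrow band remains open. Also open, going by these compounds, is whether the same insensitivity would hold with a different shared core.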